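The source may hold more compounds than are shown below. What is called first, only, known or untested is meant among the compounds shown, and "the series" means these compounds.

Three related sulfonamides have been tested in an assay on isolated protein for inhibition of malate dehydrogenase, mitochondrial (Sus scrofa), with stated times of 45 min and 30 min; a higher number here means a weaker inhibitor, a lower number a stronger inhibitor. Compound 1 `O=S(=O)(Nc1ccc(-c2nc3ccccc3o2)cc1)c1cccc(F)c1` gives > 63000 nM, which is a limit of the assay rather than a number. Compound 2 `C=Cc1ccc(S(=O)(=O)Nc2ccc3oc(-c4ccccc4)nc3c2)cc1` likewise gives > 63000 nM, again a limit. Compound 3 `O=S(=O)(Nc1ccc(-c2nc3ccccc3o2)cc1)c1ccc(F)c(C(F)(F)F)c1` gives > 63000 nM, also a limit. Compound 2 thus stands at the limit of > 63000 nM in this assay, at which 3 of the 3 values shown sit, with no measured inhibition to set it apart from the others. Compound 4 `O=S(=O)(Nc1ccc2oc(-c3ccccc3)nc2c1)c1ccc(Cl)c(Cl)c1` differs from compound 2 by 3,4-dichlorophenyl in place of 4-vinylphenyl on a sulfonyl sulfur. Among the compounds with values here, with every value so far a limit, no measured step is available to guide the expectation. The step that the limit leaves unreadable from compound 2 to compound 4 is expected to be none beyond the scatter, most likely another limit. Compound 4 is therefore estimated at 80000 nM, within 30000 nM to 300000 nM.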

Compound 4, half-maximal inhibitory concentration: > 63000 nM
Compound 4: only a limit was reported; the forecaster's own chance of this, stated with the estimate: 85%; the middle value lies beyond the limit too.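

Within the data shown here, compound 2 and compound 4 both sit at a limit of the assay rather than at a number, so no step between them can be read. The compounds shown leave open whether 3,4-dichlorophenyl in place of 4-vinylphenyl changes inhibition at all.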